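The compounds below may be only part of what the source reports. "The series", "measured", "known", "first", "only" and "open" are said of these compounds alone.

Of the compounds shown here, three built on one shared core have been measured, each carrying a different aromatic group on a carbon with a double bond to nitrogen. Compound 1 `C[C@H]1CC[C@@H]2[C@@H](OC(=O)[C@]23CC(c2c(Cl)cccc2Cl)=NO3)[C@]2(C)C(=O)C=C[C@@]12O` bears a 2,6-dichlorophenyl group there; in a functional assay on DU-145 cells (Homo sapiens) for cytotoxicity, read by sulforhodamine B assay, with a stated time of 48 h (on this read-out higher numbers stand for weaker inhibition and lower numbers for stronger inhibition), compound 1 gives 38000 nM. Compound 2 `COc1ccc(C2=NO[C@]3(C2)C(=O)O[C@@H]2[C@H]3CC[C@H](C)[C@]3(O)C=CC(=O)[C@@]23C)cc1` carries a 4-methoxyphenyl group instead, and compound 2 gives 20000 nM. Compound 3 `C[C@H]1CC[C@@H]2[C@@H](OC(=O)[C@]23CC(c2ccc(O)cc2)=NO3)[C@]2(C)C(=O)C=C[C@@]12O` carries a 4-hydroxyphenyl group, and compound 3 gives 93000 nM. Among these three numbers compound 1 sits in the middle: there is a 1.9-fold lower number from compound 1 to compound 2 (0.28 log units; within the scatter), and a 2.4-fold higher number from compound 1 to compound 3 (0.39 log units; beyond the scatter), while a 4.7-fold higher number from compound 2 to compound 3 (0.67 log units; beyond the scatter) separates the other two.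

Compound 4 `C[C@H]1CC[C@@H]2[C@@H](OC(=O)[C@]23CC(c2ccccc2[N+](=O)[O-])=NO3)[C@]2(C)C(=O)C=C[C@@]12O` has not yet been measured. It differs from compound 1 in one place: 2-nitrophenyl in place of 2,6-dichlorophenyl on a carbon with a double bond to nitrogen. Among the measured compounds shown here, no measured pair involves a 2-nitrophenyl group, so the only guide is how the assay responded to the other swaps of the aromatic group on this carbon. Those swaps moved the numbers only a little, one within the scatter and one modestly beyond it, with no clear direction. The expectation for compound 4 is therefore a number close to that of compound 1, with a 1.1-fold higher number from compound 1 to compound 4 (0.02 log units; within the scatter) not expected to exceed the scatter. The estimated value for compound 4 is 40000 nM, within a range from 15000 nM to 110000 nM.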

Compound 4, half-maximal inhibitory concentration: 34000 nM
Beside the measured number, compound 4's estimate is 1.2-fold (0.07 log units) above it; low and high end bracket the measured number.
By their numbers in this assay, from the lowest: compounds 2, 4 and 1 (each within the scatter of the next); then compound 3.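

In this assay, the 2-nitrophenyl group brings nitrogen and oxygen atoms to this carbon in place of the two chlorines of 2,6-dichlorophenyl, yet the swap gives a 1.1-fold lower number from compound 1 to compound 4 (0.05 log units; within the scatter) and so leaves the two compounds indistinguishable. Compound 4 also cannot be told apart from compound 2, with a 1.7-fold higher number from compound 2 to compound 4 (0.23 log units; within the scatter), so three quite different aromatic groups now give numbers within the scatter of each other, while a 2.7-fold lower number from compound 3 to compound 4 (0.44 log units; beyond the scatter) confirms that compound 3, with its 4-hydroxyphenyl group, stands apart as the weakest of the four. No measurement here explains why these three groups match or why compound 3 differs.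

The compounds shown all keep a single six-membered aromatic ring on this carbon, so it remains open whether a group without that ring, such as a simple amine or a longer chain, would change the number more sharply. On these data alone, it also remains open whether a 4-nitrophenyl or a 4-carboxyphenyl group would stay with compound 4 or fall with compound 3.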